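Removing a Methoxy Group from a Piperidine Dienamide

This account rests on a few compounds, and the source may have more. Where it says the series, first, only, none or still open, it means among the compounds named here.

Compound 1, `COc1cc(/C=C/C=C/C(=O)N2CCCCC2)cc(OC)c1O`, gives 32.7% in an assay for inhibition of Polyunsaturated fatty acid 5-lipoxygenase (Homo sapiens), read by spectrophotometry, tested at 20 uM; a higher number here means more inhibition at the concentration tested (going by the name of the read-out), a lower number less inhibition.
Compound 2, `COc1cc(/C=C/C=C/C(=O)N2CCCCC2)ccc1O`, gives 55.5% in this assay.
Compound 3, `COc1ccc(/C=C/C=C/C(=O)N2CCCCC2)cc1OC`, gives 51.9% in this assay.

The step from compound 1 to compound 2 is hydrogen in place of methoxy on an aromatic carbon, and it gave a number 22.8 percentage points higher from compound 1 to compound 2 (beyond the scatter). From compound 2 to compound 3 the change is methyl in place of hydrogen on an oxygen on an aromatic ring, giving a number 3.6 percentage points lower from compound 2 to compound 3 (within the scatter). The difference between the cores of compound 1 and compound 3 is not broken down here.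

Compound 4, `COc1ccc(/C=C/C=C/C(=O)N2CCCCC2)cc1`, has not been measured. It differs from compound 3 by hydrogen in place of methoxy on an aromatic carbon. Going by the values given here, this is the same kind of change as the one from compound 1 to compound 2, not the same: there the place was ortho to a hydroxy group and meta to a methoxy group, here it is ortho to a methoxy group. Because a number 22.8 percentage points higher from compound 1 to compound 2 (beyond the scatter) was a modest rise, a rise for compound 4 is expected, estimated as a number 10.1 percentage points higher from compound 3 to compound 4 (beyond the scatter) in this assay, though the different surroundings make this uncertain. Compound 4 is therefore expected to give about 62%, estimated between 42% and 80%.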

Compound 4, a percentage reported as inhibition, at one concentration (the size of the read-out at that concentration, not a potency): 42.6%
For compound 4 the middle estimate is 19.4 percentage points above the measured one; the range from low to high includes it.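

The same swap of hydrogen for methoxy did not carry over from one core to the other: in this assay the new step is a number 9.3 percentage points lower from compound 3 to compound 4 (within the scatter), so no real change can be claimed for this pair. Set side by side, the two steps disagree: the same change on two cores in this assay, a number 22.8 percentage points higher (beyond the scatter) from compound 1 to compound 2 and a number 9.3 percentage points lower (within the scatter) from compound 3 to compound 4, 32.1 percentage points apart, beyond the scatter of two such steps

This shows that the result of this change depends on the core it is made on, but two pairs cannot show which feature of the surroundings decides the outcome. The compounds shown leave open how an amine or a carboxylic acid in place of the methoxy group would read. Going by these compounds, each number is also a reading at one concentration, so potency remains open too.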